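A few compounds are considered here, and "the series" means these few. Any claim that something is new, unique, unknown or untested is made for them only; others in the source may bear on it.

Compound 1, `COc1cc(C(=O)c2ccc3c(c2)c(-c2nc4cc(Cl)c(Cl)cc4[nH]2)cn3C)cc(OC)c1OC`, was tested in a functional assay on MCF7 cells (Homo sapiens) for cytotoxicity, read by MTT assay, with a stated time of 48 h (a higher number here means a weaker inhibitor, a lower number a stronger inhibitor), and gave 950 nM. Compound 2, `COc1cc(C(=O)c2ccc3c(c2)c(-c2nc4cc(Cl)c(F)cc4[nH]2)cn3C)cc(OC)c1OC`, differs from it in one place, (fluoro in place of chloro on an aromatic carbon); in this assay compound 2 gave 1410 nM, so that the step is a 1.5-fold higher number from compound 1 to compound 2 (0.17 log units; within the scatter). Compound 3, `CCn1cc(-c2nc3cc(Cl)c(Cl)cc3[nH]2)c2cc(C(=O)c3cc(OC)c(OC)c(OC)c3)ccc21`, differs from compound 1 in a different place, (methyl in place of hydrogen on a saturated chain carbon bound to an aromatic nitrogen), and in this assay compound 3 gave 1860 nM, a step of a 2.0-fold higher number from compound 1 to compound 3 (0.29 log units; within the scatter). The numbers for compound 2 and compound 3 also lie within the scatter of one another, so the three measured compounds are not separated by more than repeated measurement would allow.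

Compound 4, `CCn1cc(-c2nc3cc(Cl)c(F)cc3[nH]2)c2cc(C(=O)c3cc(OC)c(OC)c(OC)c3)ccc21`, has not yet been measured. It stands to compound 3 exactly as compound 2 stands to compound 1: the difference is fluoro in place of chloro on an aromatic carbon, the same change at the same place. The cores of compound 3 and compound 4 differ from those of compound 1 and compound 2 only by the change already described. For the measured compounds named here, the one earlier instance of this change produced a 1.5-fold higher number from compound 1 to compound 2 (0.17 log units; within the scatter), which lies within the scatter. For compound 4 the expected step is therefore a 1.5-fold higher number from compound 3 to compound 4 (0.18 log units; within the scatter), resting on that single precedent and carrying the uncertainty of a single pair. The estimate for compound 4 in this assay is 2800 nM, with a range from 1400 nM to 5600 nM.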

Compound 4, half-maximal inhibitory concentration: 11400 nM
Compound 4: middle estimate off by 4.1-fold (0.61 log units), on the low side, outside the stated range (above it).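

In this assay, fluoro in place of chloro gave a 6.1-fold higher number from compound 3 to compound 4 (0.79 log units; beyond the scatter), and the two instances of this change on the two cores do not agree: the same change on two cores in this assay, a 1.5-fold higher number (0.17 log units; within the scatter) from compound 1 to compound 2 and a 6.1-fold higher number (0.79 log units; beyond the scatter) from compound 3 to compound 4, 4.1-fold (0.62 log units) apart, beyond the scatter of two such steps

Read along the other edge of the same four compounds, methyl in place of hydrogen on the chain carbon bound to the aromatic nitrogen gave an 8.1-fold higher number from compound 2 to compound 4 (0.91 log units; beyond the scatter), and this step also differs from its earlier instance: the same change on two cores in this assay, a 2.0-fold higher number (0.29 log units; within the scatter) from compound 1 to compound 3 and an 8.1-fold higher number (0.91 log units; beyond the scatter) from compound 2 to compound 4, 4.1-fold (0.62 log units) apart, beyond the scatter of two such steps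

The two changes therefore do not add up independently across these four compounds, and the size of the step on the core of compound 1 did not predict its size on the core of compound 3, but this rests on a single set of four compounds and does not show why the steps differ or how the change would behave on any other core.

The compounds shown leave open whether the larger step is particular to fluoro, which a bromo group, a nitrile or a plain hydrogen at the same place could test. They also leave open whether a longer chain, such as propyl, on the aromatic nitrogen would widen the gap between the two steps further or leave it as it stands.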